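Removing a methyl from the oxygen: compound 2 to compound 3

This account rests on a few compounds, and the source may have more. Where it says the series, first, only, none or still open, it means among the compounds named here.

Of the compounds shown here, two built on a shared core have been tested in a functional assay on M14 cells (Homo sapiens) for inhibition, read by sulforhodamine B assay, with a stated time of 48 h; a lower number here means a stronger inhibitor of growth, a higher number a weaker inhibitor of growth. Compound 2 `COc1cc(-c2nn(-c3cccc(NC(=O)Nc4ccc(Cl)c(Cl)c4)c3)cc2-c2ccncc2)ccc1Cl` gives 911 nM, the lower of the two numbers. Compound 1 `O=C(Nc1cccc(-n2cc(-c3ccncc3)c(-c3ccc(Cl)c(O)c3)n2)c1)Nc1cccc(C(F)(F)F)c1` gives 1400 nM, which lies within the scatter of compound 2, so the two cannot be ranked. Compound 3 `O=C(Nc1cccc(-n2cc(-c3ccncc3)c(-c3ccc(Cl)c(O)c3)n2)c1)Nc1ccc(Cl)c(Cl)c1` has not been measured. It differs from compound 2 in one place: hydrogen in place of methyl on an oxygen on an aromatic ring, that is, methoxy to hydroxy, 4-chloro-3-methoxyphenyl to 4-chloro-3-hydroxyphenyl. Compound 1 also carries a hydroxy there, but it differs from compound 3 elsewhere too, so no single step can be read from it. With nothing measured for this change, the step from compound 2 to compound 3 is expected to be a 1.1-fold higher number from compound 2 to compound 3 (0.04 log units; within the scatter), small and within the scatter. Compound 3 is therefore estimated at 1000 nM, between 400 nM and 2500 nM in this assay.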

Compound 3, concentration for 50% growth inhibition: 1180 nM
Beside the measured number, compound 3's estimate is 1.2-fold (0.07 log units) below it; the measured number falls inside the stated range.
By their numbers in this assay, from the lowest: compounds 2, 3 and 1 (each within the scatter of the next).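

In this assay, hydrogen in place of methyl on an oxygen on an aromatic ring gives a 1.3-fold higher number from compound 2 to compound 3 (0.11 log units; within the scatter) and so shows that methoxy and hydroxy at this place cannot be told apart by this read-out. Within the data shown here, compound 3 also makes the far end of the molecule readable for the first time: with the hydroxy kept, 3,4-dichlorophenyl in place of 3-(trifluoromethyl)phenyl on an amide-type nitrogen gives a 1.2-fold lower number from compound 1 to compound 3 (0.07 log units; within the scatter) and so leaves these two aryl groups unranked as well. Nothing measured here bears on why these two steps are so small.

Still open, going by these compounds, is whether a longer chain on this oxygen, or an amine in its place, would give a number beyond the scatter. With all three compounds unranked, these data do not show which part of the molecule governs growth inhibition.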